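Ethynyl for Formyl on a Spiro Core: Cytotoxicity Outlook

This account rests on a few compounds, and the source may have more. Where it says the series, first, only, none or still open, it means among the compounds named here.

Compound 1 `C=C1CC[C@@H](C(C)C)[C@]12CC=C(C=O)CC2`: 269000 nM
Compound 2 `CC1(C)CCC[C@]1(C)c1ccc(C=O)cc1`: 252000 nM
Compound 3 `C#CC1=CC[C@@]2(C)C(=C)CCC[C@]2(C)CC1`: 158000 nM

Three compounds were tested in a functional assay on HeLa cells (Homo sapiens) for cytotoxicity, read by MTT assay, with a stated time of 48 h; a lower number here means a stronger inhibitor, a higher number a weaker inhibitor. In this assay compound 1 gives 269000 nM, the highest of the three numbers, yet compound 2 with 252000 nM and compound 3 with 158000 nM both lie within the scatter of it, so no order among them can be claimed. Compound 4 `C#CC1=CC[C@]2(CC1)C(=C)CC[C@H]2C(C)C` keeps the core of compound 1 and differs in one place: ethynyl in place of formyl on a double-bonded ring carbon. Within the data shown here, no measured pair shows this change on its own. Compound 3 also carries an ethynyl and reads within the scatter of compound 1. The step of a 1.3-fold lower number from compound 1 to compound 4 (0.11 log units; within the scatter) is therefore expected to be small, with no direction beyond the scatter. Compound 4 is estimated at 210000 nM, with a range from 80000 nM to 550000 nM.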

Compound 4, half-maximal inhibitory concentration: 97600 nM
Compound 4: middle estimate off by 2.2-fold (0.33 log units), on the high side; the range from low to high includes it.
By their numbers in this assay, from the lowest: compounds 4, 3, 2 and 1 (each within the scatter of the next, the first and the last beyond it).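

In this assay, among these compounds, ethynyl in place of formyl on a double-bonded ring carbon gives a 2.8-fold lower number from compound 1 to compound 4 (0.44 log units; beyond the scatter), the first step in this set that isolates a single change. It shows that this position responds to the swap, which compounds 2 and 3, both within the scatter of compound 1, could not show. Nothing shown here explains why the number falls. The compounds shown leave open how an amine, a carboxylic acid or a longer chain would read at this position, and whether the same swap on another core gives a step of this size.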